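Removing the iodo group from compound 1

The compounds below may be only part of what the source reports. "The series", "measured", "known", "first", "only" and "open" are said of these compounds alone.

Compound 1 `COc1ccc(-c2c(I)c(=O)c3c(OC)cc(OC)cc3n2S(=O)(=O)c2ccc(OC)cc2)cc1` was tested in a functional assay on SUP-B15 cells (Homo sapiens) for antiproliferative activity, with a stated time of 72 h (on this read-out lower numbers stand for an effect already at smaller amounts and higher numbers for an effect only at larger amounts of compound), and gave 12300 nM, the highest of the two numbers recorded in this series. Compound 3 `COC(=O)c1cc(=O)c2c(OC)cc(OC)cc2n1S(=O)(=O)c1ccc(C)cc1` gave 9700 nM in this assay, a value that lies within the usual scatter of the number for compound 1. For compound 2 `COC(=O)c1cc(=O)c2c(OC)cc(OC)cc2n1C` the result in this assay is a limit rather than a number, > 37900 nM.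

Compound 4 `COc1ccc(-c2cc(=O)c3c(OC)cc(OC)cc3n2S(=O)(=O)c2ccc(OC)cc2)cc1` differs from compound 1 in one place: hydrogen in place of iodo on an aromatic carbon. Among the measured compounds shown here, no measured pair in this set isolates such a change, so the expectation rests on compound 1 alone. The step is expected to be modest, at most a little beyond the scatter, giving a 1.3-fold higher number from compound 1 to compound 4 (0.11 log units; within the scatter). Compound 4 is therefore estimated at 16000 nM, in a range from 5000 nM to 45000 nM.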

Compound 4, half-maximal effective concentration: > 82700 nM
Compound 4: only a limit was reported; the forecaster's own chance of this, stated with the estimate: 25%; middle value at least 5.1-fold (0.71 log units) away from the limit.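

Among the compounds shown here, replacing iodo with hydrogen on this aromatic carbon, ortho to a 4-methoxyphenyl group, gives an at least 6.7-fold higher number from compound 1 to compound 4 (0.82 log units; beyond the scatter), the only step here between compounds that differ in one place. For the compounds shown here, it shows that this position is not indifferent to the change, which the earlier compounds could not show. In this assay compound 4 has only a limit, not a number: the limit of > 82700 nM in this assay, at which 1 of the 4 values shown sits.

The compounds shown leave open whether iodine is specifically needed here or whether a chloro, bromo or methyl group would serve as well. As far as these compounds go, the true size of the step also remains open, as only its lower bound is given.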